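A few compounds are considered here, and "the series" means these few. Any claim that something is new, unique, unknown or untested is made for them only; others in the source may bear on it.

Compound 3 `O=Cc1ccc(-c2cn3ccnc3c(-c3ccc4ncn(Cc5ccccc5)c4c3)n2)cc1` gives 51.2% in a functional assay on MDA-MB-231 cells (Homo sapiens) for inhibition, read by sulforhodamine B assay, with a stated time of 48 h, tested at 10 uM (on this read-out lower numbers stand for less inhibition and higher numbers for more inhibition at the one concentration tested (going by the name of the read-out)), the highest of the three numbers; compound 1 `CCc1ccc(-c2cn3ccnc3c(-c3ccc4ncn(Cc5ccccc5)c4c3)n2)cc1` gives 43.2%, and compound 2 `Cc1cccc(-c2cn3ccnc3c(-c3ccc4ncn(Cc5ccccc5)c4c3)n2)c1` gives 28.4%. The step of a number 8 percentage points higher from compound 1 to compound 3 (within the scatter) lies within the scatter, while a number 22.8 percentage points higher from compound 2 to compound 3 (beyond the scatter) and a number 14.8 percentage points lower from compound 1 to compound 2 (beyond the scatter) lie beyond it. Compound 4 `c1ccc(Cn2cnc3ccc(-c4nc(-c5cccc6ccccc56)cn5ccnc45)cc32)cc1` differs from compound 3 in one place: naphthalen-1-yl in place of 4-formylphenyl on an aromatic carbon. For the measured compounds named here, no measured step brings in a naphthalen-1-yl, but the two steps leading to compound 3 show that swapping the group on this aromatic carbon shifts inhibition by modest amounts, and compound 2, which also carries no hydrogen-bond acceptor there, stands beyond the scatter below compound 3. A modest fall is therefore expected: a number 16.2 percentage points lower from compound 3 to compound 4 (beyond the scatter). The estimated value for compound 4 is 35%, ranging from 20% to 50%.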

Compound 4, a percentage reported as inhibition, at one concentration (the size of the read-out at that concentration, not a potency): 28.7%
Compound 4: the middle estimate sits 6.3 percentage points above what was measured; low and high end bracket the measured number.
By their numbers in this assay, from the lowest: compounds 2 and 4 (each within the scatter of the next); then compounds 1 and 3 (each within the scatter of the next).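

In this assay naphthalen-1-yl, with its two aromatic rings, brings no gain at this aromatic carbon: it gives a number 22.5 percentage points lower from compound 3 to compound 4 (beyond the scatter) and a number 14.5 percentage points lower from compound 1 to compound 4 (beyond the scatter) on this read-out. The step of a number 0.3 percentage points higher from compound 2 to compound 4 (within the scatter) leaves it indistinguishable from 3-methylphenyl, so the larger group matches the smaller one here. No measurement given here accounts for these differences.

From the compounds shown here alone, whether an amine or a carboxylic acid on the phenyl ring would hold or raise inhibition stays open. So does the effect of a longer chain in place of ethyl.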